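Moving a Chlorine Atom in Two Related Compound Pairs

The source may hold more compounds than are shown below. What is called first, only, known or untested is meant among the compounds shown, and "the series" means these compounds.

The measured compounds and their read-outs:

Compound 1, `CC1=C(C(=O)Nc2ccc(F)cc2)C(c2ccc([N+](=O)[O-])cc2)N=C(SCc2ccccc2Cl)N1`: in a functional assay on the whole organism (artery, strain albino) with Rattus norvegicus as the target, with a stated time of 15 min, at a dose of 10 mg/kg by the oral route (a lower number here means less inhibition, a higher number more inhibition at the dose given (going by the name of the read-out)), compound 1 gives 1.5%.
Compound 2, `CC1=C(C(=O)Nc2ccc(F)cc2)C(c2ccc([N+](=O)[O-])cc2)N=C(SCc2cccc(Cl)c2)N1`: in this assay compound 2 gives 2.1%.
Compound 3, `CC1=C(C(=O)Nc2ccc(Br)cc2)C(c2ccc(Cl)cc2Cl)N=C(SCc2ccccc2Cl)N1`: in this assay compound 3 gives 3.1%.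

All three numbers are small and lie within the usual scatter of one another, so none of the three can be set apart from the others on this evidence.

Compound 1 and compound 2 share one core and differ only in the position of a chlorine atom: 3-chlorophenyl in place of 2-chlorophenyl on a saturated chain carbon bound to a sulfur. The step this change made is a number 0.6 percentage points higher from compound 1 to compound 2 (within the scatter), which is within the scatter and therefore tells of no real shift in the read-out.

Compound 4, `CC1=C(C(=O)Nc2ccc(Br)cc2)C(c2ccc(Cl)cc2Cl)N=C(SCc2cccc(Cl)c2)N1`, is not yet measured. It stands to compound 3 as compound 2 stands to compound 1: 3-chlorophenyl in place of 2-chlorophenyl on a saturated chain carbon bound to a sulfur. The place of the change is the same in both pairs, so it is the same change, made on a second core. The difference between the two cores is not broken down here.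

Because the earlier instance of this change gave a number 0.6 percentage points higher from compound 1 to compound 2 (within the scatter), compound 4 is expected to sit close to compound 3, with an estimated step of a number 0.6 percentage points higher from compound 3 to compound 4 (within the scatter). The estimate for compound 4 in this assay is 3.7%, with a range from 0% to 12% to allow for the scatter of this kind of measurement.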

Compound 4, a percentage reported as inhibition, in the whole organism at one dose (the size of the read-out at that dose, not a potency): 1.5%
For compound 4 the middle estimate is 2.2 percentage points above the measured one; low and high end bracket the measured number.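

On the second core, moving the chlorine from 2-chlorophenyl to 3-chlorophenyl, on a saturated chain carbon bound to a sulfur, gave a number 1.6 percentage points lower from compound 3 to compound 4 (within the scatter). Set beside the first instance of this change in this assay, the new step gives no sign that the two cores respond differently to it: the same change on two cores in this assay, a number 0.6 percentage points higher (within the scatter) from compound 1 to compound 2 and a number 1.6 percentage points lower (within the scatter) from compound 3 to compound 4, 2.2 percentage points apart, within the scatter of two such steps

For the compounds shown here, this shows that, on these two cores, the change produced no step that can be told apart from the ordinary spread of repeated measurements, but it does not show that the place of the chlorine is without effect in general, as the evidence is only two pairs in one assay at one dose, all with small numbers, and neither step has a direction that can be trusted.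

The compounds shown carry only a chlorobenzyl group on the sulfur, so it remains open how the read-out would respond to a quite different group there, such as a longer chain in place of the benzyl, or an amine or a carboxylic acid on the phenyl ring. On these data alone, it also remains open whether the same change would behave alike in a compound with a much larger read-out, where a real step would be easier to see.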